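A few compounds are considered here, and "the series" means these few. Any claim that something is new, unique, unknown or untested is made for them only; others in the source may bear on it.

Compound 1, `NNC(=O)Cn1nc(N)c2c(C(F)(F)F)cc(-c3ccccc3)nc21`, carries a hydrazide on its side chain, and in a functional assay on DU-145 cells (Homo sapiens) for cytotoxicity, read by MTT assay, with a stated time of 24 h (on this read-out lower numbers stand for stronger inhibition and higher numbers for weaker inhibition), compound 1 gives 52400 nM, the highest number of the three measured compounds. Compound 2, `Nc1nn(CC(=O)NC2CCCCC2)c2nc(-c3ccccc3)cc(C(F)(F)F)c12`, gives 3100 nM, and compound 3, `CN1CCN(C(=O)Cn2nc(N)c3c(C(F)(F)F)cc(-c4ccccc4)nc32)CC1`, gives 18100 nM. Compound 4, `Nc1nn(CC(=O)N2CCCC2)c2nc(-c3ccccc3)cc(C(F)(F)F)c12`, differs from compound 1 in one place: pyrrolidin-1-yl in place of aminoamino on a carbonyl carbon.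

For the measured compounds named here, two measured steps bear on this change. Exchanging the aminoamino group of compound 1 for a cyclic amine has been seen once, as a 2.9-fold lower number from compound 1 to compound 3 (0.46 log units; beyond the scatter), a modest gain. Replacing the terminal amino group with cyclohexyl gave a larger gain, a 17-fold lower number from compound 1 to compound 2 (1.23 log units; beyond the scatter), and the difference between those two products is a 5.8-fold higher number from compound 2 to compound 3 (0.77 log units; beyond the scatter). The pyrrolidin-1-yl group of compound 4 resembles the ring of compound 3 in being a cyclic amine on the carbonyl carbon, yet it brings no hydrogen-bond donor and no acceptor, which recalls compound 2. A lower number is therefore expected for compound 4, of size a 5.2-fold lower number from compound 1 to compound 4 (0.72 log units; beyond the scatter), beyond the scatter. Compound 4 is estimated at 10000 nM, with a likely range from 4000 nM to 25000 nM.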

Compound 4, half-maximal inhibitory concentration: 12200 nM
For compound 4 the middle estimate is 1.2-fold (0.09 log units) below the measured one; measured number inside the range.
By their numbers in this assay, from the lowest: compound 2; then compounds 4 and 3 (each within the scatter of the next); then compound 1.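

In this assay, pyrrolidin-1-yl on the carbonyl carbon gives a 4.3-fold lower number from compound 1 to compound 4 (0.63 log units; beyond the scatter), so a second ring-bearing tertiary amide also improves on the hydrazide of compound 1, and the gain is not tied to 4-methylpiperazin-1-yl. The two ring amides cannot be told apart, at a 1.5-fold lower number from compound 3 to compound 4 (0.17 log units; within the scatter), whereas cyclohexylamino keeps a clear lead, with a 3.9-fold higher number from compound 2 to compound 4 (0.59 log units; beyond the scatter), and compound 2 has the lowest number of the four. Nothing measured here explains these differences.

Compound 2 differs from compound 4 in both its ring and its amide hydrogen, so the compounds shown cannot say which of the two matters. Piperidin-1-yl or cyclopentylamino on the same carbonyl carbon would help to separate them.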